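The source may report more compounds than this note shows. Statements on the series, on what has been measured and on what is new or still open speak of the compounds shown alone.

Series notes on the shared core, read in a functional assay for activation of Alpha-1A adrenergic receptor (Homo sapiens), read by calcium flux; on this read-out higher numbers stand for an effect only at larger amounts of compound and lower numbers for an effect already at smaller amounts. Compound 1 `Cc1ncc(-c2ccccc2NCC2=NCCN2)o1` gives 110 nM. Compound 2 `c1csc(-c2ccccc2NCC2=NCCN2)c1` gives 2.24 nM. Going by the values given here, the step of a 49-fold lower number from compound 1 to compound 2 (1.69 log units; beyond the scatter) is the only measured change at the aromatic carbon carrying the five-membered ring. On the numbers shown compound 2 stands lowest of the two, with compound 1 as its only neighbour, a distance beyond the scatter.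

Compound 3 `Cc1noc(-c2ccccc2NCC2=NCCN2)n1` carries the change (3-methyl-1,2,4-oxadiazol-5-yl in place of thiophen-2-yl on an aromatic carbon). Among the compounds with values here, the single measured step that bears on this change is a 49-fold lower number from compound 1 to compound 2 (1.69 log units; beyond the scatter), which was large; the 3-methyl-1,2,4-oxadiazol-5-yl entering here resembles the 2-methyl-1,3-oxazol-5-yl of compound 1 far more than it resembles thiophen-2-yl, so a step of similar size, in the opposite direction, is the expectation. For compound 3 the estimated step is a 67-fold higher number from compound 2 to compound 3 (1.83 log units; beyond the scatter), a large rise. Compound 3 is accordingly expected at 150 nM, within a range from 30 nM to 800 nM.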

Compound 3, half-maximal effective concentration: 661 nM
Estimate against measurement, compound 3: 4.4-fold (0.64 log units) below; the measured number falls inside the stated range.
By their numbers in this assay, from the lowest: compound 2; then compound 1; then compound 3.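

In this assay a second replacement of thiophen-2-yl on this aromatic carbon gives a 300-fold higher number from compound 2 to compound 3 (2.47 log units; beyond the scatter), so thiophen-2-yl holds the lowest number of the three and both methyl-bearing rings sit well above it. Those two rings are not interchangeable either: the change between them gives a 6.0-fold higher number from compound 1 to compound 3 (0.78 log units; beyond the scatter), a modest step but one beyond the scatter, and smaller than the steps that separate either ring from thiophen-2-yl. Nothing available here accounts for these differences.

Compound 1 and compound 3 both differ from compound 2 in carrying a methyl group as well as further ring hetero atoms, so the shown compounds do not separate these two changes. A 5-methylthiophen-2-yl group or an unsubstituted 1,3-oxazol-5-yl group on the same carbon would pull them apart.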